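Nitro position swap on the difluoronitrophenyl arm of compound 2

This account rests on a few compounds, and the source may have more. Where it says the series, first, only, none or still open, it means among the compounds named here.

The series shares the core shown in compound 1 `COC(=O)c1ccc(CN(CCCc2c(N)nc(N)nc2O)c2cc(F)cc(F)c2[N+](=O)[O-])cc1`, carrying a difluoronitrophenyl group on the amine nitrogen of the chain. In a functional assay on CCRF-CEM cells (Homo sapiens) for cytotoxicity, in the absence of a further agent (a lower number here means a stronger inhibitor, a higher number a weaker inhibitor), compound 1 gives only a limit of the assay, > 100000 nM. Compound 2 `Nc1nc(N)c(CCCN(Cc2ccc(NC(CCC(=O)O)C(=O)O)cc2)c2cc(F)cc(F)c2[N+](=O)[O-])c(O)n1` likewise gives only a limit of the assay in this assay, > 100000 nM. The step that the two limits leave unreadable from compound 1 to compound 2 is therefore unreadable, because the limit of > 100000 nM in this assay, at which 2 of the 3 values shown sit, ties both ends to the same limit. Compound 3 `Nc1nc(N)c(CCCNc2cc(F)c([N+](=O)[O-])cc2[N+](=O)[O-])c(O)n1` differs from compound 2 in several places. In this assay, going by the values given here, compound 3 gives 1000 nM, the only number in the set.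

Compound 4 `Nc1nc(N)c(CCCN(Cc2ccc(NC(CCC(=O)O)C(=O)O)cc2)c2ccc([N+](=O)[O-])c(F)c2F)c(O)n1` keeps every atom of compound 2 and changes only (2,3-difluoro-4-nitrophenyl in place of 3,5-difluoro-2-nitrophenyl on an amine nitrogen). Among the compounds with values here, no measured step bears on this rearrangement; the single measured step is unreadable and compound 3 is not a one-place neighbour. With compound 2 at a limit, the step of an at least 3.3-fold lower number from compound 2 to compound 4 (0.52 log units; beyond the scatter) is expected to be undetermined in size and a gain cannot be excluded. Compound 4 is estimated at 30000 nM in this assay, within 4000 nM to 200000 nM, with a substantial chance that only a limit is again reported.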

Compound 4, half-maximal inhibitory concentration: > 100000 nM
Compound 4: only a limit was reported; the forecaster's own chance of this, stated with the estimate: 45%; middle value at least 3.3-fold (0.52 log units) from the limit.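

Compound 4, like compound 2, gives only a limit in this assay, so no new step can be read between them: the limit of > 100000 nM in this assay, at which 3 of the 4 values shown sit. The compounds shown leave open whether 2,3-difluoro-4-nitrophenyl in place of 3,5-difluoro-2-nitrophenyl on the amine nitrogen shifts the value at all.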